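This account rests on a few compounds, and the source may have more. Where it says the series, first, only, none or still open, it means among the compounds named here.

Three compounds share one core. Compound 1 `CC(C)(CO)COC1(c2ccc(Cl)cc2)c2ccccc2C(=O)N1Cc1ccccc1` gives 82000 nM in a functional assay on HCT-116 cells (Homo sapiens) for inhibition, read by fluorescence, with a stated time of 48 h; on this read-out higher numbers stand for weaker inhibition of growth and lower numbers for stronger inhibition of growth. Compound 2 `CC(=O)OCC(C)(C)COC1(c2ccc(Cl)cc2)c2ccccc2C(=O)N1Cc1ccc(Cl)cc1` gives 70000 nM, the second highest of the three numbers, and compound 3 `CC(C)(COC(=O)[C@@H](N)c1ccccc1)COC1(c2ccc(Cl)cc2)c2ccccc2C(=O)N1Cc1ccc(Cl)cc1` gives 38000 nM. For the measured compounds named here, the only single-place step measured, a 1.8-fold lower number from compound 2 to compound 3 (0.27 log units; within the scatter), stays within the scatter.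

Compound 4 `O=C1c2ccccc2C(OCCCO)(c2ccc(Cl)cc2)N1Cc1ccc(Cl)cc1` differs from compound 2 by 2-hydroxyethyl in place of 1-(acetoxymethyl)-1-methylethyl on a saturated chain carbon bound to an oxygen on a saturated carbon. Going by the values given here, no measured step covers this change, but the values of compound 1 and compound 2 show that an ester and an alcohol on this chain sit within the scatter of each other, so no step beyond the scatter is expected: a 1.1-fold higher number from compound 2 to compound 4 (0.06 log units; within the scatter). For compound 4 the estimated value is 80000 nM, expected between 35000 nM and 180000 nM.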

Compound 4, concentration for 50% growth inhibition: 68000 nM
Beside the measured number, compound 4's estimate is 1.2-fold (0.07 log units) above it; measured number inside the range.
By their numbers in this assay, from the lowest: compounds 3, 4, 2 and 1 (each within the scatter of the next, the first and the last beyond it).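

In this assay, exchanging 2-(acetoxymethyl)-2-methylpropyl for 3-hydroxypropyl gives a 1.0-fold lower number from compound 2 to compound 4 (0.01 log units; within the scatter). At this position, then, the chain can lose both its acetate ester and its branching, and gain a free hydroxyl, with no change in growth inhibition beyond the scatter. No measurement available here explains this result. From the compounds shown here alone, whether an amine or a carboxylic acid on this chain, or a longer chain, would move the number beyond the scatter remains open. So does whether a simple methoxy group would be tolerated at this position.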